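A few compounds are considered here, and "the series" means these few. Any claim that something is new, unique, unknown or untested is made for them only; others in the source may bear on it.

Series notes. Compound 1 `C/C(=N/NC(=O)Nc1nnc(COc2ccc3ccccc3c2)o1)c1ccc([N+](=O)[O-])cc1`, compound 2 `C/C(=N/NC(=O)Nc1nnc(COc2ccc3ccccc3c2)o1)c1ccc(Cl)cc1` and compound 3 `COc1ccc(/C=N\NC(=O)Nc2nnc(COc3ccc4ccccc4c3)o2)cc1` share one core and differ only in the group carried on an amide-type nitrogen. In a functional assay on the whole organism (strain Swiss albino) with Mus musculus as the target, with a stated time of 4 h (a higher number here means that more compound is needed for the effect, a lower number that less compound is needed), compound 1 gives 300 mg/kg, compound 2 gives 300 mg/kg and compound 3 gives 300 mg/kg. The step of no change at the digits printed from compound 1 to compound 2 (within the scatter) and the step of no change at the digits printed from compound 2 to compound 3 (within the scatter) both leave the dose where it was, so compound 3 stands level with compounds 1 and 2. Compound 4 `C/C(=N/NC(=O)Nc1nnc(COc2ccc3ccccc3c2)o1)c1ccc(N)cc1` follows with a group of 10 heavy atoms (8 carbon, 2 nitrogen; one six-membered aromatic ring of carbon only) in place of a group of 10 heavy atoms (8 carbon, 1 nitrogen, 1 oxygen; one six-membered aromatic ring of carbon only), on an amide-type nitrogen. Both measured steps bear on this: each exchanged the group on the same amide-type nitrogen with no effect beyond the scatter, so for no change at the digits printed from compound 3 to compound 4 (within the scatter) no step beyond the scatter is expected either. Compound 4 is accordingly expected to give 300 mg/kg, in a range from 150 mg/kg to 600 mg/kg.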

Compound 4, minimum effective dose: 300 mg/kg
Compound 4: middle estimate and measured number agree at the digits printed; the measured number falls inside the stated range.
By their numbers in this assay, from the lowest: compounds 1, 2, 3 and 4 (each within the scatter of the next).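

In this assay, a group with a hydrogen-bond donor on the aromatic ring replaces one without on the amide-type nitrogen, and the result is no change at the digits printed from compound 3 to compound 4 (within the scatter). Amino on an aromatic carbon likewise gives no change at the digits printed from compound 2 to compound 4 (within the scatter) and no change at the digits printed from compound 1 to compound 4 (within the scatter), so amino joins nitro and chloro with no step beyond the scatter. Nothing available accounts for this flat result. Still open, on these data alone, is whether a carboxylic acid on that aromatic carbon, or an open alkyl chain in place of the whole group on the amide-type nitrogen, would shift the dose at all.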